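Swapping an amine end on a quinazoline styrene

The source may hold more compounds than are shown below. What is called first, only, known or untested is meant among the compounds shown, and "the series" means these compounds.

Measured compounds:
compound 1, `CC(C)N(CCNc1nc(/C=C/c2ccc([N+](=O)[O-])cc2)nc2ccccc12)C(C)C`, 29100 nM
compound 2, `O=[N+]([O-])c1ccc(/C=C/c2nc(NCCN3CCCCC3)c3ccccc3n2)cc1`, 27600 nM
compound 3, `CC(C)N(CCNc1nc(/C=C/c2ccc([N+](=O)[O-])cc2)nc2ccc(Cl)cc12)C(C)C`, 17300 nM

All three were tested in a functional assay on MGC-803 cells (Homo sapiens) for cytotoxicity, read by MTT assay, with stated times of 48 h and 4 h; a lower number here means a stronger inhibitor, a higher number a weaker inhibitor. Compound 1 and compound 2 share a core and differ only at the end of the side chain: piperidin-1-yl in place of diisopropylamino on a saturated chain carbon, two bonds along the chain from a nitrogen on an aromatic ring. That change gave a 1.1-fold lower number from compound 1 to compound 2 (0.02 log units; within the scatter), so the two compounds cannot be told apart on this read-out. Compound 3 differs from compound 1 in the core itself: chloro in place of hydrogen on an aromatic carbon. That step reads a 1.7-fold lower number from compound 1 to compound 3 (0.23 log units; within the scatter), again too small to carry weight.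

Compound 4, `O=[N+]([O-])c1ccc(/C=C/c2nc(NCCN3CCCCC3)c3cc(Cl)ccc3n2)cc1`, has not yet been measured in this assay. It carries the core of compound 3 and the side chain of compound 2, so the change from compound 3 to compound 4 is piperidin-1-yl in place of diisopropylamino on a saturated chain carbon, two bonds along the chain from a nitrogen on an aromatic ring. The place of the change is the same as in the step from compound 1 to compound 2, so this is the same change made on a core that differs by the chloro just described.

Among the compounds with values here, the only earlier example of this change, from compound 1 to compound 2, left the number essentially where it was. Compound 4 is therefore expected to sit close to compound 3, with an expected step of a 1.1-fold lower number from compound 3 to compound 4 (0.03 log units; within the scatter) in this assay, because the measured 1.1-fold lower number from compound 1 to compound 2 (0.02 log units; within the scatter) was so small. Compound 4 is estimated at 16000 nM, with a range from 8000 nM to 32000 nM, resting on a single prior example of the change.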

Compound 4, half-maximal inhibitory concentration: 20000 nM
The estimate for compound 4 lay 1.3-fold (0.10 log units) below the measured number; the range from low to high includes it.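

In this assay, piperidin-1-yl in place of diisopropylamino on the chlorinated core gave a 1.2-fold higher number from compound 3 to compound 4 (0.06 log units; within the scatter), and the same swap on the core without chloro behaved no differently: the same change on two cores in this assay, a 1.1-fold lower number (0.02 log units; within the scatter) from compound 1 to compound 2 and a 1.2-fold higher number (0.06 log units; within the scatter) from compound 3 to compound 4, 1.2-fold (0.09 log units) apart, within the scatter of two such steps. Read the other way round, chloro in place of hydrogen with the piperidin-1-yl side chain gave a 1.4-fold lower number from compound 2 to compound 4 (0.14 log units; within the scatter), which agrees with the same step on the diisopropylamino side chain: the same change on two cores in this assay, a 1.7-fold lower number (0.23 log units; within the scatter) from compound 1 to compound 3 and a 1.4-fold lower number (0.14 log units; within the scatter) from compound 2 to compound 4, 1.2-fold (0.09 log units) apart, within the scatter of two such steps. Together these four compounds show that neither change moves the number by more than the scatter on either partner structure, but they do not show that a change with a large effect would carry from one core to another, since no step here is big enough to put that to the test.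

The compounds shown leave open whether a different amine end, such as morpholine or dimethylamino, or a longer chain leading to the piperidin-1-yl group, would shift the number beyond the scatter. They also leave open whether bromo or methoxy in place of chloro, or a nitrile in place of the nitro group, would give the same step on both side chains.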